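Swapping the sulfonyl aryl group on a weak HSP60/HSP10 inhibitor

A few compounds are considered here, and "the series" means these few. Any claim that something is new, unique, unknown or untested is made for them only; others in the source may bear on it.

The series shares a core carrying a sulfonamide, and its members differ only in the group on the sulfonyl sulfur. Among the compounds with values here, compound 1 `O=S(=O)(Nc1ccc(-c2nc3ccccc3o2)cc1)c1ccc(Cl)s1` is the one member that gives a number in an assay on cells for inhibition of HSP60/HSP10 (Homo sapiens), with a stated time of 60 min (on this read-out lower numbers stand for stronger inhibition and higher numbers for weaker inhibition), where compound 1 gives 31000 nM. Compound 2 `Cc1ccccc1S(=O)(=O)Nc1ccc2oc(-c3ccccc3)nc2c1` gives only a limit of the assay in this assay, > 100000 nM. Compound 3 `O=S(=O)(Nc1ccc2oc(-c3ccccc3)nc2c1)c1cccc(F)c1` likewise gives only a limit in this assay, > 100000 nM. Within the data shown here, the single measured step, a step that the two limits leave unreadable from compound 2 to compound 3, therefore cannot be read in size, as both of its values sit at the limit of > 100000 nM in this assay, at which 2 of the 3 values shown sit.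

Compound 4 `O=S(=O)(Nc1ccc(-c2nc3ccccc3o2)cc1)c1ccc(O)cc1` is not yet measured. It differs from compound 1 as 4-hydroxyphenyl in place of 5-chlorothiophen-2-yl on a sulfonyl sulfur. Among the measured compounds shown here, no measured step touches the 5-chlorothiophen-2-yl group or the 4-hydroxyphenyl group, so nothing here speaks to the direction or size of this change. The estimate for compound 4 in this assay is therefore centred close to compound 1, at 50000 nM, within 15000 nM to 150000 nM. The step expected from this estimate, a 1.6-fold higher number from compound 1 to compound 4 (0.21 log units; within the scatter), is not expected to exceed the usual scatter.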

Compound 4, half-maximal inhibitory concentration: 78000 nM
The estimate for compound 4 lay 1.6-fold (0.19 log units) below the measured number; the range from low to high includes it.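

On the sulfonyl sulfur, 4-hydroxyphenyl in place of 5-chlorothiophen-2-yl gives the series its first readable step in this assay, a 2.5-fold higher number from compound 1 to compound 4 (0.40 log units; beyond the scatter). The group at this place can therefore move the number beyond the scatter on this core, and here the change from a five-membered aromatic ring with a hetero atom to a six-membered ring of carbon only goes with weaker inhibition. Compound 4 still gives a number, whereas compound 2 and compound 3 each give only a limit of the assay: the limit of > 100000 nM in this assay, at which 2 of the 4 values shown sit.

The compounds shown do not separate the departure of the chlorine from the change of ring or the arrival of the hydroxyl. Going by these compounds, whether an unsubstituted phenyl, a 4-methoxyphenyl or a 5-methylthiophen-2-yl group at this place would move the number, and in which direction, stays open.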